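The compounds below may be only part of what the source reports. "The series", "measured", "known", "first", "only" and "open" are said of these compounds alone.

Measured compounds in a functional assay on SNB-19 cells (Homo sapiens) for cytotoxicity, read by sulforhodamine B assay, with a stated time of 48 h; on this read-out lower numbers stand for stronger inhibition of growth and higher numbers for weaker inhibition of growth:
- compound 1 `ClCc1ccc(Cn2cnc3c(Cl)ncnc32)cc1` gives 3630 nM
- compound 2 `Nc1nc(Cl)c2ncn(Cc3ccc(CCl)cc3)c2n1` gives 6760 nM

Of the compounds shown here, two carry numbers so far. Compound 2 and compound 1 differ at a single site of the shared core, and the step recorded for that change in this assay, a 1.9-fold higher number from compound 1 to compound 2 (0.27 log units; within the scatter), stays within the scatter. On the numbers shown, compound 2 therefore stands together with compound 1; no separation beyond repeat variation is visible between the two.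

Compound 3 `ClCc1ccc(Cn2cnc3c(Cl)nc(Cl)nc32)cc1` is the next member and has not yet been measured. It differs from compound 2 in one place: chloro in place of amino on an aromatic carbon, the position being on an aromatic carbon of a six-membered aromatic ring with 2 nitrogen, part of a fused or bridged system of two rings, between two ring nitrogen atoms.

Going by the values given here, no measured step puts a chloro group at that carbon. Among the compounds with values here, the only step that bears on the site, a 1.9-fold higher number from compound 1 to compound 2 (0.27 log units; within the scatter), shows that substitution there left the read-out within the scatter. On that basis no step beyond the scatter is expected in this assay for compound 3, and the estimated change is a 1.5-fold lower number from compound 2 to compound 3 (0.18 log units; within the scatter). Compound 3 is accordingly estimated at 4500 nM, with a range from 1500 nM to 14000 nM.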

Compound 3, concentration for 50% growth inhibition: 2510 nM
For compound 3 the middle estimate is 1.8-fold (0.25 log units) above the measured one; the measured number falls inside the stated range.
By their numbers in this assay, from the lowest: compounds 3, 1 and 2 (each within the scatter of the next, the first and the last beyond it).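

In this assay the carbon between two ring nitrogen atoms now gives its first step beyond the scatter: chloro in place of amino gives a 2.7-fold lower number from compound 2 to compound 3 (0.43 log units; beyond the scatter) as a modest change. Chloro in place of hydrogen at the same carbon gives a 1.4-fold lower number from compound 1 to compound 3 (0.16 log units; within the scatter) and so does not separate compound 3 from compound 1, which means the site responds only in the contrast between amino and chloro, with the hydrogen of compound 1 lying within the scatter of both. Going by these compounds alone, the series so far therefore runs as a chain in which only the two ends, compound 2 and compound 3, stand apart, and nothing available bears on why these two groups part at this carbon.

From the compounds shown here alone, whether a methoxy group, a methylamino group or a longer chain at this carbon would sit with amino or with chloro remains open. Also open, going by these compounds, is whether the step from amino to chloro would hold with an amine in place of the chloro group meta to this carbon, and in any read-out other than this assay as well.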